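Swapping a Hydroxyphenyl Arm on a Pyridine Core

The source may report more compounds than this note shows. Statements on the series, on what has been measured and on what is new or still open speak of the compounds shown alone.

Compound 1 `Oc1ccc(-c2cc(-c3cccc(O)c3)nc(-c3ccccc3O)c2)cc1` is the stronger of two measured compounds: in a functional assay on T47D cells (Homo sapiens) for cytotoxicity, read by CCK-8 assay, with a stated time of 4 days (on this read-out lower numbers stand for stronger inhibition and higher numbers for weaker inhibition), compound 1 gives 4810 nM, while compound 2 `Oc1ccc(-c2cc(-c3ccc(O)cc3)nc(-c3ccccc3O)c2)cc1` gives 50000 nM. Within the data shown here, the single measured step, a 10-fold higher number from compound 1 to compound 2 (1.02 log units; beyond the scatter), shows what one such exchange can do. Compound 3 `Oc1cccc(-c2cc(-c3cccc(O)c3)nc(-c3ccccc3O)c2)c1` differs from compound 1 by 3-hydroxyphenyl in place of 4-hydroxyphenyl on an aromatic carbon. Among the measured compounds shown here, this change runs opposite to the measured step, so the number is expected to fall, although no second example confirms the size. The estimate for compound 3 is 1500 nM, between 500 nM and 5000 nM, corresponding to a 3.2-fold lower number from compound 1 to compound 3 (0.51 log units; beyond the scatter).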

Compound 3, half-maximal inhibitory concentration: 50000 nM
Estimate against measurement, compound 3: 33-fold (1.52 log units) below, and the stated range ends below it.
By their numbers in this assay, from the lowest: compound 1; then compounds 2 and 3 (each within the scatter of the next).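

At the carbon opposite the ring nitrogen, the 4-hydroxyphenyl of compound 1 proves to matter: in this assay, 3-hydroxyphenyl in its place gives a 10-fold higher number from compound 1 to compound 3 (1.02 log units; beyond the scatter). The exchange keeps the same atoms and alters only where the hydroxyl sits on that ring, so the position of this one hydroxyl can weigh heavily here. No available evidence explains the loss. Still open, from the compounds shown here alone, is how an amine or a carboxylic acid on this ring, in place of the hydroxyl, would compare with compound 1.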